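Dropping the Chlorine from Compound 3

The source may report more compounds than this note shows. Statements on the series, on what has been measured and on what is new or still open speak of the compounds shown alone.

Compound 3 `Nc1ccccc1NC(=O)c1ccc(CSC(=S)N2CCN(c3ccc(Cl)cc3)CC2)cc1` stands at the top of the three measured numbers in a functional assay on HeLa cells (Homo sapiens) for antiproliferative activity, read by CCK-8 assay, with a stated time of 72 h, tested at 2 uM (on this read-out lower numbers stand for a weaker effect and higher numbers for a stronger effect at the one concentration tested), where compound 3 gives 51.2%. For comparison, compound 1 `Nc1ccccc1NC(=O)c1ccc(CSC(=S)N2CCN(Cc3ccccn3)CC2)cc1` gives 14.2% in this assay, and compound 2 `Nc1ccccc1NC(=O)c1ccc(CSC(=S)N2CCN(C(c3ccccc3)c3ccccc3)CC2)cc1` gives 8%. Going by the values given here, the only measured single-place step is a number 37 percentage points higher from compound 1 to compound 3 (beyond the scatter), which put 4-chlorophenyl in place of (pyridin-2-yl)methyl on an amine nitrogen in a ring.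

Compound 4 `Nc1ccccc1NC(=O)c1ccc(CSC(=S)N2CCN(c3ccccc3)CC2)cc1` differs from compound 3 by hydrogen in place of chloro on an aromatic carbon. Among the compounds with values here, no measured step removes this chloro alone. The one large step known replaced the whole group on the nitrogen at once; how much of that gain remains when only the chloro is removed is not shown by the data. With the ring kept and only the chloro gone, a moderate loss is expected rather than a return to the low numbers of compound 1 or compound 2. Compound 4 is therefore expected to give 35% in this assay, within a range from 15% to 55%. That estimate corresponds to an expected step of a number 16.2 percentage points lower from compound 3 to compound 4 (beyond the scatter), downward but uncertain in size.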

Compound 4, a percentage reported as inhibition, at one concentration (the size of the read-out at that concentration, not a potency): 62.2%
For compound 4 the middle estimate is 27.2 percentage points below the measured one; the whole stated range lies below it.
By their numbers in this assay, from the lowest: compounds 2 and 1 (each within the scatter of the next); then compound 3; then compound 4.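

Removing the chloro costs nothing here: in this assay the change gives a number 11 percentage points higher from compound 3 to compound 4 (beyond the scatter), so this position on the aromatic ring, para to a large group, does not need a chlorine for the effect seen at this concentration. The earlier large gain therefore did not depend on the chloro, since plain phenyl in place of (pyridin-2-yl)methyl gives a number 48 percentage points higher from compound 1 to compound 4 (beyond the scatter). Why hydrogen gives the higher number at this position cannot be said, as no supporting data bear on it.

Still open, from the compounds shown here alone, is whether a fluoro, methyl or methoxy group at the same position would read like the chloro or like hydrogen. Each number also comes from one concentration, so it gives the size of the effect there, not a potency.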